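A few compounds are considered here, and "the series" means these few. Any claim that something is new, unique, unknown or untested is made for them only; others in the source may bear on it.

Measured so far in a functional assay on MDA-MB-231 cells (Homo sapiens) for antiproliferative activity, read by sulforhodamine B assay, with a stated time of 72 h; on this read-out higher numbers stand for weaker inhibition and lower numbers for stronger inhibition
- compound 1 `Cc1ccc(S(=O)(=O)Nc2cc(SCC(=O)N[C@@H](CC(C)C)B(O)O)c(O)c3ccccc23)cc1` gives 14000 nM
- compound 2 `CC(C)C[C@H](NC(=O)CSc1cc(NS(=O)(=O)c2ccc(Cl)cc2)c2ccccc2c1O)B(O)O` gives 6190 nM

Compound 1 has the higher of these two numbers, which makes it the weaker inhibitor of the pair. The step followed here leads from it to compound 3 `CC(=O)Nc1ccc(S(=O)(=O)Nc2cc(SCC(=O)N[C@@H](CC(C)C)B(O)O)c(O)c3ccccc23)cc1` and puts acetamido in place of methyl on an aromatic carbon, para to a large group (acetamido in place of methyl on an aromatic carbon). Put another way, 4-methylphenyl becomes 4-acetamidophenyl.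

For the measured compounds named here, only one measured step changes this same methyl. That step, a 2.3-fold lower number from compound 1 to compound 2 (0.35 log units; beyond the scatter) in which chloro takes the place of methyl, is modest. Going by the values given here, it is a single example with a different incoming group, and no measured compound carries acetamido, so it gives only a weak hint of direction and a rough guide to size. A small move toward a lower number is therefore expected in this assay and a move the other way cannot be excluded. The expected change is a 1.4-fold lower number from compound 1 to compound 3 (0.15 log units; within the scatter) and this rests on very little data. For compound 3 the estimated value is 10000 nM with an expected range from 4000 nM to 30000 nM until a measurement settles it.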

Compound 3, half-maximal inhibitory concentration: 4450 nM
Compound 3: the middle estimate sits 2.2-fold (0.35 log units) above what was measured; the measured number falls inside the stated range.
By their numbers in this assay, from the lowest: compounds 3 and 2 (each within the scatter of the next); then compound 1.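

Replacing methyl with acetamido gives a 3.1-fold lower number from compound 1 to compound 3 (0.50 log units; beyond the scatter) in this assay and so adds a second group at this position, para to a large group, that lowers the number relative to methyl; no compound shown goes against this. Acetamido brings 4 heavy atoms, a hydrogen-bond donor and a hydrogen-bond acceptor where methyl had 1 heavy atom and neither donor nor acceptor, yet the comparison with chloro gives a 1.4-fold lower number from compound 2 to compound 3 (0.14 log units; within the scatter) and so does not separate these two very different groups, which shows that the added size here comes with no loss against methyl. Nothing available explains why either group gives a lower number than methyl.

On these data alone, it remains open whether an amine, a carboxylic acid or a longer amide chain at this position would keep the number as low as in compound 2 and compound 3, or whether a bare hydrogen would already do as well as these groups. As far as these compounds go, all three values also come from one cell line, so whether the same ranking holds in other cells remains unknown.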